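The source may hold more compounds than are shown below. What is called first, only, known or untested is meant among the compounds shown, and "the series" means these compounds.

Compound 1 `NCc1ccccc1CN(Cc1nc2ccccc2[nH]1)C1CCCc2cccnc21` gives 28 nM in a functional assay on CEM-CCRF cells for antagonist activity at C-X-C chemokine receptor type 4 (Homo sapiens), read by calcium flux; on this read-out higher numbers stand for weaker inhibition and lower numbers for stronger inhibition.
Compound 2 `NCc1ccc(CN(Cc2nc3ccccc3[nH]2)C2CCCc3cccnc32)c(CN)c1` gives 10 nM in this assay.

Compound 1 stands highest of the two numbers shown; its nearest neighbour is compound 2, reached by a 2.8-fold lower number from compound 1 to compound 2 (0.45 log units; beyond the scatter) through an aminomethyl in place of hydrogen on an aromatic carbon. Compound 3 `NCc1cscc1N(Cc1nc2ccccc2[nH]1)C1CCCc2cccnc21` differs from compound 1 by a group of 7 heavy atoms (5 carbon, 1 nitrogen, 1 sulfur; one five-membered aromatic ring with 1 hetero atom) in place of a group of 9 heavy atoms (8 carbon, 1 nitrogen; one six-membered aromatic ring of carbon only), on an amine nitrogen. For the measured compounds named here, no measured step bears directly on this change; the single step from compound 1 to compound 2 concerns a different position and gives no guidance on the direction. Compound 3 is therefore expected, with wide uncertainty, at 60 nM, in a range from 15 nM to 300 nM. That estimate corresponds to an expected 2.1-fold higher number from compound 1 to compound 3 (0.33 log units; beyond the scatter).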

Compound 3, half-maximal inhibitory concentration: 13 nM
For compound 3 the middle estimate is 4.6-fold (0.66 log units) above the measured one; the measured number lies below the stated range.
By their numbers in this assay, from the lowest: compounds 2 and 3 (each within the scatter of the next); then compound 1.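

On the amine nitrogen, the 2-(aminomethyl)benzyl group of compound 1 gives way to a group of fewer heavy atoms, with a five-membered aromatic ring holding sulfur, and this assay records a 2.2-fold lower number from compound 1 to compound 3 (0.33 log units; beyond the scatter). Among these compounds, then, a six-membered aromatic ring of carbon only is not needed at this place. Nothing measured here accounts for this shift. Still open, going by these compounds, is whether a furan or pyridine ring would serve equally at this nitrogen. Also open, on these data alone, is how a longer amine chain or a carboxylic acid in place of the aminomethyl would fare.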